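This account rests on a few compounds, and the source may have more. Where it says the series, first, only, none or still open, it means among the compounds named here.

Benzyl amide in place of methyl on a nitro-bearing benzothiazole? No — avoid ring names. Title below.

A Larger Amide Substituent Added to a Nitro Analogue

Measured compounds:
compound 1, `O=C(CSc1nc2ccc(NC(=O)c3ccccc3)cc2s1)NCc1ccc(Cl)cc1`, 33700 nM
compound 2, `CNC(=O)CSc1nc2ccc(NC(=O)c3ccc([N+](=O)[O-])cc3)cc2s1`, > 100000 nM

In a functional assay on MCF7 cells (Homo sapiens) for cytotoxicity, read by MTT assay, with a stated time of 48 h (on this read-out higher numbers stand for weaker inhibition and lower numbers for stronger inhibition), compound 1 gives 33700 nM. Compound 2 is reported only as a limit of the assay, > 100000 nM, so no number is known for it; it stands at the limit of > 100000 nM in this assay, at which 1 of the 2 values shown sits. Compound 3, `O=C(CSc1nc2ccc(NC(=O)c3ccc([N+](=O)[O-])cc3)cc2s1)NCc1ccc(Cl)cc1`, has not yet been measured in this assay. It differs from compound 2 in one place: 4-chlorophenyl in place of hydrogen on a saturated chain carbon bound to an amide-type nitrogen. Within the data shown here, no step between two measured compounds covers this change directly, so its size must be guessed. Compound 1 carries the same (4-chlorobenzyl)carbamoyl group and gives a number rather than a limit, which is the only anchor available. Compound 3 is therefore expected to gain activity relative to compound 2, the step of an at least 2.5-fold lower number from compound 2 to compound 3 (0.39 log units; beyond the scatter) lying beyond the scatter, because compound 1 gives 33700 nM with that same amide substituent. Compound 3 is estimated at 40000 nM in this assay, with a range from 15000 nM to 110000 nM, and a fair chance that only a limit is reported.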

Compound 3, half-maximal inhibitory concentration: > 100000 nM
Compound 3: only a limit was reported; the forecaster's own chance of this, stated with the estimate: 30%; at least 2.5-fold (0.39 log units) between middle value and limit.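

In this assay compound 3 is reported only as a limit of the assay, and so is compound 2: the limit of > 100000 nM in this assay, at which 2 of the 3 values shown sit. The step between these two compounds cannot be read, so adding 4-chlorophenyl to the methyl carbon of the amide gives no number for the nitro analogue, and the (4-chlorobenzyl)carbamoyl group alone does not bring this analogue into the measurable range. The readable comparison lies elsewhere: with that amide group held fixed, nitro in place of hydrogen on an aromatic carbon gives an at least 2.9-fold higher number from compound 1 to compound 3 (0.47 log units; beyond the scatter), so the measurable activity of compound 1 does not carry over once the nitro group is present.

As far as these compounds go, neither limit gives a number, so it stays open whether the amide substituent matters at all while the nitro group is in place. From the compounds shown here alone, it is also open whether an amine or a carboxylic acid on that same aromatic carbon would leave the compound at the limit or bring it back towards compound 1.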